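The source may hold more compounds than are shown below. What is called first, only, known or untested is meant among the compounds shown, and "the series" means these compounds.

In an in vitro ADME assay on microsomes (Homo sapiens) for metabolic stability (a lower number here means that the compound disappears faster, a higher number that the compound lasts longer), compound 3 `CCc1nc(N(CC2CC2)CC2CC2)c(CC)nc1-c1ccc(Cl)cc1Cl` gives 0.133 h. That lies within the scatter of compound 2 `CCc1nc(-c2ccc(Cl)cc2Cl)c(CC)nc1NC(C1CC1)C1CC1` at 0.183 h, and both sit well under compound 1 `CCc1nc(NC(CC)CC)c(OC)nc1-c1ccc(OC(F)F)cc1Cl` at 2 h. Compound 4 `CCc1nc(-c2ccc(Cl)cc2Cl)c(CC)nc1NC(C)CN(C)C` brings ((1-((dimethylamino)methyl)ethyl)amino in place of bis(cyclopropylmethyl)amino on an aromatic carbon). For the measured compounds named here, the one measured step at this place is a 1.4-fold lower number from compound 2 to compound 3 (0.14 log units; within the scatter), a swap between two amino groups that both carry three-membered rings, so it says little about a group with no ring. Compound 1, at 2 h, also has an amino group without a ring, but it differs elsewhere too, which makes it only a weak hint towards a higher number. The expected change is a 3.0-fold higher number from compound 3 to compound 4 (0.48 log units; beyond the scatter), a modest and uncertain rise. For compound 4 the estimated half-life is 0.4 h, with an expected range from 0.13 h to 1.2 h.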

Compound 4, half-life: 0.117 h
Beside the measured number, compound 4's estimate is 3.4-fold (0.53 log units) above it; measured number outside the range, below it.
By their numbers in this assay, from the lowest: compounds 4, 3 and 2 (each within the scatter of the next); then compound 1.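

Measured in this assay, putting (1-((dimethylamino)methyl)ethyl)amino in place of bis(cyclopropylmethyl)amino gives a 1.1-fold lower number from compound 3 to compound 4 (0.06 log units; within the scatter), and putting 1-((dimethylamino)methyl)ethyl in place of dicyclopropylmethyl on the nitrogen gives a 1.6-fold lower number from compound 2 to compound 4 (0.19 log units; within the scatter). Across these three compounds, then, losing the three-membered rings and gaining a second nitrogen in this group leaves the half-life within the scatter. No measurement at hand explains this result. Still open, as far as these compounds go, is whether a carboxylic acid, an amide or a longer chain at this position would move the half-life beyond the scatter. From the compounds shown here alone, whether the same swap behaves alike on the core of compound 1 is also open.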